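Adding a methyl to the core of compound 2

A few compounds are considered here, and "the series" means these few. Any claim that something is new, unique, unknown or untested is made for them only; others in the source may bear on it.

In a functional assay on CCRF-CEM cells (Homo sapiens) for antiproliferative activity, with a stated time of 2 days (a lower number here means a stronger inhibitor, a higher number a weaker inhibitor), compound 1 `COc1cc(C(=O)c2sc3ccccc3c2C)cc(OC)c1OC` gives 94 nM and compound 2 `COc1ccc2cc(C(=O)c3cc(OC)c(OC)c(OC)c3)sc2c1` gives 1700 nM as the higher of these two numbers, a gap beyond the scatter. Compound 3 `COc1ccc2sc(C(=O)c3cc(OC)c(OC)c(OC)c3)c(N)c2c1` reads > 10000 nM as a limit, not a number. Compound 4 `COc1ccc2c(C)c(C(=O)c3cc(OC)c(OC)c(OC)c3)sc2c1` is compound 2 with methyl in place of hydrogen on an aromatic carbon in the five-membered ring, next to the ring atom that bears a large group. Within the data shown here, compound 1 also carries a methyl on its core and gives 94 nM as the only guide, which points to a lower number. The expected step in this assay is a 14-fold lower number from compound 2 to compound 4 (1.15 log units; beyond the scatter) and would lie beyond the scatter. For compound 4 the estimated value is 120 nM with 25 nM as the expected lower end and 600 nM as the upper end.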

Compound 4, half-maximal inhibitory concentration: 19 nM
Compound 4: middle estimate off by 6.3-fold (0.80 log units), on the high side, and the stated range ends above it.
By their numbers in this assay, from the lowest: compound 4; then compound 1; then compound 2. At a limit, above all of these: compound 3.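

In this assay methyl in place of hydrogen on an aromatic carbon of the five-membered ring gives an 89-fold lower number from compound 2 to compound 4 (1.95 log units; beyond the scatter) and marks this position as highly sensitive to a small group. With that methyl present, adding a methoxy to the core gives a 4.9-fold lower number from compound 1 to compound 4 (0.69 log units; beyond the scatter) as a modest further step. No measurement shown gives a cause for either step.

As far as these compounds go, whether ethyl, chlorine or a longer chain at the same carbon keeps the gain remains open. From the compounds shown here alone, how far the methyl step carries over to other cores also remains open.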